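The compounds below may be only part of what the source reports. "The series", "measured", "known", "first", "only" and "open" are said of these compounds alone.

Measured compounds in an assay on isolated protein for inhibition of Death-associated protein kinase 3 (Homo sapiens), tested at 1 uM; on this read-out higher numbers stand for a stronger effect at the one concentration tested and lower numbers for a weaker effect:
- compound 1 `O=C1OC(c2ccc(Cl)c([N+](=O)[O-])c2)=N/C1=C\c1ccncc1` gives 0%
- compound 2 `O=C1OC(c2ccc(Cl)c([N+](=O)[O-])c2)=N/C1=C\c1cccnc1` gives 100%
- compound 3 `O=C1OC(c2ccc(Cl)cc2Cl)=N/C1=C\c1cccnc1` gives 42%

Compound 1 stands lowest of the three numbers in this assay; compound 3 is nearest and compound 2 furthest. Going by the values given here, the one single-place step known here, a number 100 percentage points higher from compound 1 to compound 2 (beyond the scatter), concerns the pyridinyl ring, not the other ring. Compound 4 `O=C1OC(c2cccc([N+](=O)[O-])c2)=N/C1=C\c1ccncc1` differs from compound 1 by hydrogen in place of chloro on an aromatic carbon. Among the compounds with values here, no measured step bears on this change, so it gives no guidance on its own; the only anchor is the reading of compound 1 itself. On that basis, the expected step is a number 5 percentage points higher from compound 1 to compound 4 (within the scatter), no change beyond the scatter. Compound 4 is therefore estimated at 5%, within 0% to 30%.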

Compound 4, a percentage reported as inhibition, at one concentration (the size of the read-out at that concentration, not a potency): 0%
Compound 4: middle estimate off by 5 percentage points, on the high side, and the stated range covers the measured number.
By their numbers in this assay, from the lowest: compounds 1 and 4 (each within the scatter of the next); then compound 3; then compound 2.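

In this assay, replacing the chloro with hydrogen on this aromatic carbon gives no change at the digits printed from compound 1 to compound 4 (within the scatter), so with the pyridin-4-yl group in place, the chloro makes no visible difference. Both compounds read at the bottom of the scale, where any further loss could not show, so this says little about the chloro in a compound that reads higher. No measured evidence explains this result. From the compounds shown here alone, whether hydrogen would do the same with the pyridin-3-yl group of compound 2 stays open, as does the effect of a methoxy group or an amine on this carbon.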